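The compounds below may be only part of what the source reports. "The series", "measured", "known", "first", "only" and "open" are said of these compounds alone.

Working notes on the series

Two pairs of aryl compounds are followed in an assay on isolated protein for inhibition of kynurenine--oxoglutarate transaminase 1 (Homo sapiens), read by HPLC, with a stated time of 20 min; a lower number here means a stronger inhibitor, a higher number a weaker inhibitor. Compound 1 `CCOC(=O)/C(CCCC(=O)O)=N\Nc1ccc(Cl)cc1` gives 20000 nM. Compound 2 `CCOC(=O)/C(CCCC(=O)O)=N\Nc1ccc([N+](=O)[O-])cc1` gives 179000 nM. The change between them, (nitro in place of chloro on an aromatic carbon), brings a 9.0-fold higher number from compound 1 to compound 2 (0.95 log units; beyond the scatter). Compound 3 `O=C(O)CCc1c(C(=O)O)[nH]c2ccc(Cl)cc12` rests on a different core; how this core differs from that of compound 1 is not broken down here. Compound 3 gives 293000 nM. Compound 4 `O=C(O)CCc1c(C(=O)O)[nH]c2ccc([N+](=O)[O-])cc12` carries the same kind of change, (nitro in place of chloro on an aromatic carbon), but around the place the ring is here part of a fused or bridged system of two rings, meta to a fused ring and para to a fused ring, where in compound 1 the place was para to a large group. The step is expected to be a 5.1-fold higher number from compound 3 to compound 4 (0.71 log units; beyond the scatter), resting on the rise seen in a 9.0-fold higher number from compound 1 to compound 2 (0.95 log units; beyond the scatter) together with compound 3 at 293000 nM. Compound 4 is thus estimated at 1500000 nM, between 400000 nM and 6000000 nM, with a fair chance that only a limit is reported.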

Compound 4, half-maximal inhibitory concentration: 666000 nM
Compound 4: the middle estimate sits 2.3-fold (0.35 log units) above what was measured; the measured number falls inside the stated range.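

In this assay, nitro in place of chloro on an aromatic carbon gives a higher number on the second core as well, with a 2.3-fold higher number from compound 3 to compound 4 (0.36 log units; beyond the scatter). The direction of the change therefore carries from one core to the other in these two pairs, but its size does not: the same change on two cores in this assay, a 9.0-fold higher number (0.95 log units; beyond the scatter) from compound 1 to compound 2 and a 2.3-fold higher number (0.36 log units; beyond the scatter) from compound 3 to compound 4, 3.9-fold (0.60 log units) apart, beyond the scatter of two such steps

Two pairs set no rule for any further core, and they do not show which difference between the cores goes with the gap between the steps.

The compounds shown leave open how an amine or a fluoro group in that place would read on either core. Also open, going by these compounds, is whether a longer chain on the core of compound 3 would alter the size of the step.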